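Nitro to Amino Exchange Across Two Related Cores

A few compounds are considered here, and "the series" means these few. Any claim that something is new, unique, unknown or untested is made for them only; others in the source may bear on it.

Compound 1 `COc1ccc(NC(=O)c2cc(OC)c(OC)c(OC)c2)cc1[N+](=O)[O-]` and compound 2 `COc1ccc(NC(=O)c2cc(OC)c(OC)c(OC)c2)cc1N` share one core, while compound 3 `COc1ccc(C(=O)Oc2cc(OC)c(OC)c(OC)c2)cc1[N+](=O)[O-]` and compound 4 `COc1ccc(C(=O)Oc2cc(OC)c(OC)c(OC)c2)cc1N` share another; the difference between the two cores is not broken down here. In a functional assay on HT-29 cells (Homo sapiens) for antiproliferative activity, read by MTT assay, with a stated time of 72 h (a higher number here means a weaker inhibitor, a lower number a stronger inhibitor), compound 1 gives 9700 nM and compound 2 gives 1200 nM. The change amino in place of nitro on an aromatic carbon produced an 8.1-fold lower number from compound 1 to compound 2 (0.91 log units; beyond the scatter). Compound 3 reaches only a limit of the assay, > 100000 nM, so no number stands for it (the limit of > 100000 nM in this assay, at which 1 of the 3 values shown sits). For the measured compounds named here, the same change, (amino in place of nitro on an aromatic carbon), is made from compound 3 to compound 4; as compound 3 offers only a limit, no measured step can be placed beside the earlier one. Compound 4 is expected to show an at least 2.5-fold lower number from compound 3 to compound 4 (0.39 log units; beyond the scatter), a step that rests on an 8.1-fold lower number from compound 1 to compound 2 (0.91 log units; beyond the scatter). The estimate for compound 4 in this assay is 40000 nM, expected to fall between 8000 nM and 200000 nM, with a further limit remaining possible.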

Compound 4, half-maximal inhibitory concentration: > 100000 nM
Compound 4: only a limit was reported; the forecaster's own chance of this, stated with the estimate: 45%; middle value at least 2.5-fold (0.39 log units) from the limit.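

Compound 3 and compound 4 both stand at a limit of this assay, so no step can be read between them: the limit of > 100000 nM in this assay, at which 2 of the 4 values shown sit.

The compounds shown leave open whether amino in place of nitro changes activity at all on the core of compound 3.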